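Swapping Fluoro for Methyl: Predicting Compound 4

The compounds below may be only part of what the source reports. "The series", "measured", "known", "first", "only" and "open" are said of these compounds alone.

Compound 1, `O=C1NC(=O)/C(=C\c2ccc(OCC(=O)N3N=C(c4ccccc4)CC3c3ccc(F)cc3)cc2)S1`, gives 1700 nM in an assay on cells for inhibition of histone deacetylase 4 (Homo sapiens), read by fluorescence, with a stated time of 30 min; on this read-out higher numbers stand for weaker inhibition and lower numbers for stronger inhibition.
Compound 2, `Cc1ccc(C2CC(c3ccccc3)=NN2C(=O)COc2ccc(/C=C3/SC(=O)NC3=O)cc2)cc1`, gives 1200 nM in this assay.
Compound 3, `O=C1NC(=O)/C(=C\c2ccc(OCC(=O)N3N=C(c4ccc(F)cc4F)CC3c3ccc(F)cc3)cc2)S1`, gives 1500 nM in this assay.

Of the compounds shown here, three sharing one core have been measured; a fourth, compound 4, `Cc1ccc(C2CC(c3ccc(F)cc3F)=NN2C(=O)COc2ccc(/C=C3/SC(=O)NC3=O)cc2)cc1`, has not. Compound 1 and compound 2 differ in a single place: methyl in place of fluoro on an aromatic carbon. This change gave a 1.4-fold lower number from compound 1 to compound 2 (0.15 log units; within the scatter). Compound 1 and compound 3 also differ in a single place, this time within the core itself: 2,4-difluorophenyl in place of phenyl on a carbon with a double bond to nitrogen. That change gave a 1.1-fold lower number from compound 1 to compound 3 (0.05 log units; within the scatter). All three measured values lie close to one another, so none can be called stronger or weaker than the rest.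

Compound 4 stands to compound 3 as compound 2 stands to compound 1. The difference is methyl in place of fluoro on an aromatic carbon, the same change that separates compound 1 from compound 2, made at the same place on the ring. Among the compounds with values here, only that one earlier example of the change is available, so the expectation rests on a single step. That step, from compound 1 to compound 2, was a 1.4-fold lower number from compound 1 to compound 2 (0.15 log units; within the scatter). The step from compound 3 to compound 4 in this assay is expected to be of similar size, a 1.4-fold lower number from compound 3 to compound 4 (0.13 log units; within the scatter). Compound 4 is therefore expected to give about 1100 nM, with a likely range from 550 nM to 2200 nM.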

Compound 4, half-maximal inhibitory concentration: 1500 nM
For compound 4 the middle estimate is 1.4-fold (0.13 log units) below the measured one; measured number inside the range.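

Putting methyl in place of fluoro on the core that carries 2,4-difluorophenyl gave no change at the digits printed from compound 3 to compound 4 (within the scatter) in this assay, and the comparison with the earlier example of this change reads: the same change on two cores in this assay, a 1.4-fold lower number (0.15 log units; within the scatter) from compound 1 to compound 2 and no change at the digits printed (within the scatter) from compound 3 to compound 4, 1.4-fold (0.15 log units) apart, within the scatter of two such steps. The other change, 2,4-difluorophenyl in place of phenyl, gave a 1.3-fold higher number from compound 2 to compound 4 (0.10 log units; within the scatter), and it too can be set beside its earlier example: the same change on two cores in this assay, a 1.1-fold lower number (0.05 log units; within the scatter) from compound 1 to compound 3 and a 1.3-fold higher number (0.10 log units; within the scatter) from compound 2 to compound 4, 1.4-fold (0.15 log units) apart, within the scatter of two such steps. Within the data shown here, both changes therefore look alike on the two cores, but every step here lies within the scatter, so this shows only that neither change produced a readable difference in these four compounds, not that a real effect carries from one core to another.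

Going by these compounds, the series shows only fluoro and methyl on this aromatic carbon, so it remains open whether a methoxy group, an amine or a carboxylic acid in the same place would give a step beyond the scatter. If such a step appeared, it would also remain to be seen whether it kept its size on both cores, which would be a far stronger test of carrying a change across than steps as small as these.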